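Adding one methyl to a weakly active compound

This account rests on a few compounds, and the source may have more. Where it says the series, first, only, none or still open, it means among the compounds named here.

Compound 1 `O=C(Nc1cccc2cccnc12)c1cnc(Cl)cn1`: 9300 nM
Compound 2 `O=C(Nc1cccc2cccnc12)c1ncccn1`: > 10000 nM (a limit, not a number)

Both compounds were tested in a functional assay on PANC-1 cells (Homo sapiens) for inhibition, read by MTT assay, with a stated time of 72 h; a lower number here means a stronger inhibitor, a higher number a weaker inhibitor. Compound 2 stands at the limit of > 10000 nM in this assay, at which 1 of the 2 values shown sits. This is a limit of the assay, so the true position of compound 2 on the scale is not known.

Compound 3 `Cc1ccc2cccc(NC(=O)c3ncccn3)c2n1` differs from compound 2 in one place: methyl in place of hydrogen on an aromatic carbon. This is methyl in place of hydrogen on an aromatic carbon, next to the ring nitrogen. For the measured compounds named here, no pair of measured compounds shows what such a change does, so no shift beyond the scatter is expected, and another limit is quite possible. Going by the values given here, the only true number so far, for compound 1, is 9300 nM, which also points to a weak result. The expected step is a step that the limit leaves unreadable from compound 2 to compound 3. The estimate for compound 3 is 11000 nM, with an expected range of 4500 nM to 27000 nM.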

Compound 3, half-maximal inhibitory concentration: > 10000 nM
Compound 3 was reported as a limit (the forecaster's own chance of this, stated with the estimate: 60%); the middle value is on the limit's open side.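

Compound 3 gives > 10000 nM, which is a limit and not a number. For the compounds shown here, compound 2 also stands at a limit, so no step from compound 2 to compound 3 can be read: the limit of > 10000 nM in this assay, at which 2 of the 3 values shown sit.

The compounds shown leave open whether the added methyl changes activity at all, and in which direction.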